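The source may report more compounds than this note shows. Statements on the series, on what has been measured and on what is new or still open speak of the compounds shown alone.

Compound 1 `Cc1ccc(NC(=O)CSc2nncnc2-c2cccc3ccccc23)c(Br)c1`, compound 2 `O=C(CSc1nncnc1-c1cccc2ccccc12)N1CCc2ccccc2C1` and compound 3 `O=C(CSc1nncnc1-c1cccc2ccccc12)Nc1ccccc1[N+](=O)[O-]` share one core and differ only in the group on the carbonyl carbon. In an ADME assay on MT4 cells (Homo sapiens) for cytotoxicity, read by MTT assay (on this read-out lower numbers stand for higher toxicity in this test and higher numbers for lower toxicity in this test), compound 1 gives 166000 nM, compound 2 gives 13000 nM and compound 3 gives 142000 nM. Compound 3 therefore stands second highest of the three numbers, close to compound 1 and far from compound 2, as the steps of a 1.2-fold lower number from compound 1 to compound 3 (0.07 log units; within the scatter) and an 11-fold higher number from compound 2 to compound 3 (1.04 log units; beyond the scatter) show. The unmeasured compound 4 `O=C(CSc1nncnc1-c1cccc2ccccc12)Nc1ccc(Cl)cc1Cl` differs from compound 3 by 2,4-dichlorophenyl in place of 2-nitrophenyl on an amide-type nitrogen. For the measured compounds named here, the one step that bears directly on this change is the swap of one aromatic amide substituent for another, a 1.2-fold lower number from compound 1 to compound 3 (0.07 log units; within the scatter), which stayed within the scatter. The large step of a 13-fold lower number from compound 1 to compound 2 (1.11 log units; beyond the scatter) arose from a different kind of change, replacing an arylamino group by a cyclic amine, and so does not bear on a swap between two arylamino groups. On that basis the account expects no step beyond the scatter for compound 4, namely a 1.1-fold higher number from compound 3 to compound 4 (0.02 log units; within the scatter), and estimates compound 4 in this assay at 150000 nM, with a range from 60000 nM to 320000 nM.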

Compound 4, half-maximal cytotoxic concentration: 254000 nM
Estimate against measurement, compound 4: 1.7-fold (0.23 log units) below, within the range that was stated.
By their numbers in this assay, from the lowest: compound 2; then compounds 3, 1 and 4 (each within the scatter of the next).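

In this assay, the swap of 2-nitrophenyl for 2,4-dichlorophenyl on an amide-type nitrogen gives a 1.8-fold higher number from compound 3 to compound 4 (0.25 log units; within the scatter), and a 1.5-fold higher number from compound 1 to compound 4 (0.18 log units; within the scatter) also stays within the scatter, so the three substituted phenyl groups on this nitrogen read alike. The entering group has no hydrogen-bond acceptors while the leaving group had them, yet this difference brought no step beyond the scatter. With a 20-fold higher number from compound 2 to compound 4 (1.29 log units; beyond the scatter), compound 2, which carries 1,2,3,4-tetrahydroisoquinolin-2-yl, remains the only one of the four set apart.

Nothing measured here gives a reason for these readings. The compounds shown leave open whether an open-chain amine such as diethylamino on the carbonyl carbon would read like compound 2 or like the arylamino compounds, and whether a carboxylic acid on the phenyl ring would stay within the same scatter.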